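This account rests on a few compounds, and the source may have more. Where it says the series, first, only, none or still open, it means among the compounds named here.

In a functional assay on K562 cells (Homo sapiens) for cytotoxicity, read by trypan blue exclusion, with a stated time of 96 h (on this read-out higher numbers stand for weaker inhibition and lower numbers for stronger inhibition), three compounds have numbers so far:

Compound 1, `COc1ccc(/C=C/S(=O)(=O)Cc2ccc(OC)c(N)c2)cc1`: 2500 nM
Compound 2, `COc1ccc(CS(=O)(=O)/C=C/c2c(OC)cccc2OC)c(N)c1`: 750 nM
Compound 3, `COC(=O)CCNc1cc(CS(=O)(=O)/C=C/c2c(OC)cc(OC)cc2OC)ccc1OC`: 1000 nM

Compound 3 sits with compound 2 inside the usual scatter of this assay, so the two cannot be told apart on these numbers. Compound 1 is the one that stands away from compound 3, with a higher number that lies beyond the scatter, and it is also the compound whose core carries the fewest methoxy groups. Among the measured compounds shown here, no pair of these three differs in one place only, so no single-change step is available to lean on.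

Compound 4, `COc1cc(OC)c(/C=C/S(=O)(=O)Cc2ccc(OC)c(N[C@@H](C)C(=O)O)c2)c(OC)c1`, has not yet been measured. It keeps the core of compound 3 and differs from it in one place: 1-carboxyethyl in place of 2-(methoxycarbonyl)ethyl on a nitrogen on an aromatic ring. For the measured compounds named here, since no step between measured compounds speaks to this kind of exchange, the expectation for this assay rests on the position of compound 3 alone. A modest step toward a higher number is expected, one that may not clearly exceed the scatter, so that a 2.0-fold higher number from compound 3 to compound 4 (0.30 log units; within the scatter) is the estimated size. On that basis compound 4 is expected to give about 2000 nM in this assay, with a plausible range from 600 nM to 6000 nM.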

Compound 4, half-maximal inhibitory concentration: 15 nM
For compound 4 the middle estimate is 130-fold (2.12 log units) above the measured one; the measured number lies below the stated range.
By their numbers in this assay, from the lowest: compound 4; then compounds 2 and 3 (each within the scatter of the next); then compound 1.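

In this assay, among the compounds shown here, exchanging 2-(methoxycarbonyl)ethyl for 1-carboxyethyl on a nitrogen on an aromatic ring gives a 67-fold lower number from compound 3 to compound 4 (1.82 log units; beyond the scatter) and so shows that this position can carry a large change in the read-out, which the earlier compounds, with no single-change step among them, could not show. The exchange alters several things at once: a methyl ester gives way to a carboxylic acid, the group goes from 6 heavy atoms to 5, a hydrogen-bond donor enters, and a defined stereocentre appears on the carbon attached to the nitrogen. Nothing available here accounts for the size of this step.

The compounds shown leave open which of these features goes with the step, since a 2-carboxyethyl group would keep the acid on the unbranched chain, whereas a 1-(methoxycarbonyl)ethyl group would keep the branch and stereocentre with the ester. They also leave open how the opposite configuration at that stereocentre, or a simple carboxymethyl group on the same nitrogen, would read in this assay on this core.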